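This account rests on a few compounds, and the source may have more. Where it says the series, first, only, none or still open, it means among the compounds named here.

- compound 1 `O=C(/C=C1\CCc2c1ccc(F)c2F)NC1CC1` gives 62 mg/kg
- compound 2 `O=C(/C=C1\CCc2cc(F)ccc21)NC1CC1` gives 81 mg/kg

In a functional assay on the whole organism with Mus musculus as the target (on this read-out lower numbers stand for an effect already at smaller amounts and higher numbers for an effect only at larger amounts of compound), compound 1 stands within the scatter of compound 2, so the two cannot be ranked. Compound 3 (`NC(=O)/C=C1\CCc2c1ccc(F)c2F`) keeps the core of compound 1 but differs in one group (hydrogen in place of cyclopropyl on an amide-type nitrogen), with hydrogen in place of cyclopropyl on an amide-type nitrogen. For the measured compounds named here, the only measured step (a 1.3-fold higher number from compound 1 to compound 2 (0.12 log units; within the scatter)) swaps a group on an aromatic carbon, so it offers only a weak guide, and nothing measured here tests a change on this nitrogen. No direction can be argued, and only a small change is expected (a 1.0-fold lower number from compound 1 to compound 3 (0.01 log units; within the scatter)). Compound 3 is estimated at 60 mg/kg (expected range 20 mg/kg to 180 mg/kg).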

Compound 3, dose for half-maximal effect: 45 mg/kg
Estimate against measurement, compound 3: 1.3-fold (0.12 log units) above; the measured number falls inside the stated range.
By their numbers in this assay, from the lowest: compounds 3, 1 and 2 (each within the scatter of the next).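

In this assay, hydrogen in place of cyclopropyl on the amide-type nitrogen gives a 1.4-fold lower number from compound 1 to compound 3 (0.14 log units; within the scatter) and so leaves the two compounds unranked. For the compounds shown here, this is the first reading at this nitrogen, since the earlier step touched only an aromatic carbon, and here the cyclopropyl compound and the unsubstituted amide cannot be told apart. No measurement at hand explains this result. As far as these compounds go, whether a methyl, a longer chain or a phenyl ring on this nitrogen would give a number beyond the scatter remains open. So does whether the same swap would read alike on the core of compound 2.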